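Replacing a Benzamide with a Phenylurea in a CCR1 Series

A few compounds are considered here, and "the series" means these few. Any claim that something is new, unique, unknown or untested is made for them only; others in the source may bear on it.

Measured so far:
- compound 1, `CC(C)C(NC(=O)c1ccccc1)C(=O)N1CCN(c2ccc(Cl)cc2)CC1`: 525 nM
- compound 2, `CC(C)[C@@H](NC(=O)c1cccc(F)c1)C(=O)N1CCC(c2ccc(Cl)cc2)CC1`: 24 nM
- compound 3, `CCCC(NC(=O)c1ccccc1C)C(=O)N1CCC(c2ccc(Cl)cc2)CC1`: 152 nM

All three compounds were tested in an assay on THP-1 cells for displacement of a labelled ligand from C-C chemokine receptor type 1 (Homo sapiens); on this read-out higher numbers stand for weaker inhibition and lower numbers for stronger inhibition. Compound 2 gives 24 nM, the lowest of the three numbers and therefore the strongest inhibition shown here; the next nearest is compound 3 at 152 nM, and compound 1 at 525 nM lies furthest away, both gaps beyond the scatter. No two of the measured compounds differ in only one place, so no single change can be tied to a measured step.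

Compound 4, `CC(C)[C@@H](NC(=O)Nc1ccccc1)C(=O)N1CCC(c2ccc(Cl)cc2)CC1`, has not yet been measured in this assay. It differs from compound 2 in one place: anilino in place of 3-fluorophenyl on a carbonyl carbon. The change turns a benzamide into a phenylurea while keeping the rest of the structure unchanged. Nothing in the measured set shows how this assay responds to a urea in place of an amide, so the expectation rests on compound 2 alone. A modest weakening is expected, with the estimated step from compound 2 to compound 4 being a 2.5-fold higher number from compound 2 to compound 4 (0.40 log units; beyond the scatter). Compound 4 is therefore expected to give about 60 nM, within a range of 15 nM to 250 nM.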

Compound 4, half-maximal inhibitory concentration: 616 nM
Compound 4: middle estimate off by 10-fold (1.01 log units), on the low side; the whole stated range lies below it.
By their numbers in this assay, from the lowest: compound 2; then compound 3; then compounds 1 and 4 (each within the scatter of the next).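

In this assay, among the compounds shown here, anilino in place of 3-fluorophenyl on a carbonyl carbon gives a 26-fold higher number from compound 2 to compound 4 (1.41 log units; beyond the scatter), a large step and the first single change in this set whose effect can be read directly. It shows that this position is sensitive to what sits on the carbonyl carbon, even though the leaving and entering groups both carry one six-membered aromatic ring of carbon only and neither carries a net charge. Two things change together here, as the fluorine leaves and the hydrogen-bond donor of the anilino enters, and nothing available bears on why the number rises so far.

Open, as far as these compounds go, is whether the rise follows the new nitrogen or the lost fluorine, a question that a plain phenyl on the same carbonyl carbon would help to settle. Also open, from the compounds shown here alone, is whether a urea can work at this position at all with a different aryl group, such as 3-fluoroanilino, or with a methylated anilino that no longer has the hydrogen-bond donor.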